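Swapping the Aromatic Ester Group on Compound 2

The compounds below may be only part of what the source reports. "The series", "measured", "known", "first", "only" and "open" are said of these compounds alone.

Measured in a functional assay on K562 cells (Homo sapiens) for cytotoxicity, read by MTT assay; a lower number here means a stronger inhibitor, a higher number a weaker inhibitor:
compound 1 `CCC(=O)Oc1cc(/C=C/C(=O)c2ccc(OC)c3c2OC(C)(C)C=C3)ccc1OC` gives 160 nM
compound 2 `COc1ccc(/C=C/C(=O)c2ccc(OC)c3c2OC(C)(C)C=C3)cc1OC(=O)c1ccc(Br)cc1` gives 1110 nM

Compound 2 holds the higher of the two numbers. Compound 3 `COc1ccc(/C=C/C(=O)Oc2cc(/C=C/C(=O)c3ccc(OC)c4c3OC(C)(C)C=C4)ccc2OC)cc1` has not been measured and differs from compound 2 by 2-(4-methoxyphenyl)ethenyl in place of 4-bromophenyl on a carbonyl carbon. Among the compounds with values here, only one measured step bears on this change: a 6.9-fold higher number from compound 1 to compound 2 (0.84 log units; beyond the scatter), when 4-bromophenyl replaced ethyl on that carbonyl carbon. Here, both the leaving and the entering group carry one six-membered aromatic ring of carbon only, so no shift beyond the scatter is expected in this assay. The estimated change is a 1.4-fold lower number from compound 2 to compound 3 (0.14 log units; within the scatter). Compound 3 is expected at 800 nM, with an estimated range of 250 nM to 2500 nM.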

Compound 3, half-maximal inhibitory concentration: 380 nM
Compound 3: the middle estimate sits 2.1-fold (0.32 log units) above what was measured; the range from low to high includes it.
By their numbers in this assay, from the lowest: compound 1; then compound 3; then compound 2.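

In this assay, two groups that each carry one six-membered aromatic ring of carbon only do not read alike on this carbonyl carbon, with a 2.9-fold lower number from compound 2 to compound 3 (0.47 log units; beyond the scatter) for 2-(4-methoxyphenyl)ethenyl in place of 4-bromophenyl. Ethyl still holds the lowest number of the three, with a 2.4-fold higher number from compound 1 to compound 3 (0.38 log units; beyond the scatter) when 2-(4-methoxyphenyl)ethenyl replaces it. No measurement at hand accounts for these differences.

Still open, on these data alone, is how a longer chain than ethyl, or an amine, would read on this carbonyl carbon. Also open, as far as these compounds go, is whether the double bond or the methoxy group of 2-(4-methoxyphenyl)ethenyl matters to the number.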